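A few compounds are considered here, and "the series" means these few. Any claim that something is new, unique, unknown or untested is made for them only; others in the source may bear on it.

For the measured compounds named here, in an ADME assay on BV-2 cells (Mus musculus) for cytotoxicity, read by MTT assay, with a stated time of 48 h, tested at 20 uM (on this read-out higher numbers stand for a weaker effect at the one concentration tested and lower numbers for a stronger effect), compound 2 `Cc1ccc(S(=O)(=O)n2cc(/C=N\c3ccc(N4CCOCC4=O)cc3)c3ccccc32)cc1` gives 56.7%, the lowest of the three numbers measured so far. Compound 1 `O=C1COCCN1c1ccc(/N=C\c2c[nH]c3ccccc23)cc1` gives 104% and compound 3 `O=C1COCCN1c1ccc(/N=C\c2cn(C(=O)c3ccc(Cl)cc3)c3ccccc23)cc1` gives 99%. Compound 4 `O=C1COCCN1c1ccc(/N=C\c2cn(Cc3ccc(F)cc3)c3ccccc23)cc1` differs from compound 2 by 4-fluorobenzyl in place of (4-methylphenyl)sulfonyl on an aromatic nitrogen. Going by the values given here, two measured steps bear on this change: a number 42.3 percentage points higher from compound 2 to compound 3 (beyond the scatter), and in the opposite direction a number 47.3 percentage points lower from compound 1 to compound 2 (beyond the scatter). Both show that the (4-methylphenyl)sulfonyl on the aromatic nitrogen goes with the low number, while hydrogen or (4-chlorophenyl)carbonyl at that place leave the number near that of compound 1, as a number 5 percentage points lower from compound 1 to compound 3 (within the scatter) shows. A 4-fluorobenzyl at the same place is therefore expected to move the number back up by a large step, a number 38.3 percentage points higher from compound 2 to compound 4 (beyond the scatter). Compound 4 is expected to give 95%, within a range from 70% to 110%.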

Compound 4, a percentage reported as activity, at one concentration (the size of the read-out at that concentration, not a potency): 84.2%
Compound 4: middle estimate off by 10.8 percentage points, on the high side, within the range that was stated.
By their numbers in this assay, from the lowest: compound 2; then compound 4; then compounds 3 and 1 (each within the scatter of the next).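

With a 4-fluorobenzyl on the aromatic nitrogen, this assay shows an intermediate level rather than a return to that of the unsubstituted compound: a number 27.5 percentage points higher from compound 2 to compound 4 (beyond the scatter) is only part of the way up, while a number 19.8 percentage points lower from compound 1 to compound 4 (beyond the scatter) and a number 14.8 percentage points lower from compound 3 to compound 4 (beyond the scatter) both place it below the other two. Losing the (4-methylphenyl)sulfonyl is therefore not enough to restore the number of compound 1, and of the three groups compared with hydrogen, only (4-chlorophenyl)carbonyl stays within the scatter of it.

Open, on these data alone, is whether a plain benzyl without the fluorine, a methylsulfonyl or an aminoethyl chain on this nitrogen would fall at the level of compound 2 or of compound 4. No measurement at hand accounts for these differences.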